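A few compounds are considered here, and "the series" means these few. Any claim that something is new, unique, unknown or untested is made for them only; others in the source may bear on it.

Compound 3 `Cn1c(Cc2nn(C)c(=O)c3ccccc23)nnc1SCCCCCCCC(=O)Oc1ccc(Cl)cc1Cl` gives 800 nM in an assay on isolated protein (Mus musculus) for inhibition of IL15-IL15 receptor (Homo sapiens), read by resazurin assay, with stated times of 30 min and 2.5 days (a lower number here means a stronger inhibitor, a higher number a weaker inhibitor), the lowest of the three numbers in hand. Compound 1 `Cn1c(Cc2nn(C)c(=O)c3ccccc23)nnc1SCCCCCCCC(=O)Nc1ccc(Br)cc1Br` gives 1500 nM, and the step of a 1.9-fold lower number from compound 1 to compound 3 (0.27 log units; within the scatter) lies within the scatter, so these two cannot be ordered. Compound 2 `CCCCCCCCCCSc1nnc(Cc2nn(C)c(=O)c3ccccc23)n1C` gives 7600 nM; the step of a 9.5-fold lower number from compound 2 to compound 3 (0.98 log units; beyond the scatter) is beyond the scatter, as is a 5.1-fold higher number from compound 1 to compound 2 (0.70 log units; beyond the scatter). Compound 4 `CC(C)Oc1ccc(NC(=O)CCCCCCCSc2nnc(Cc3nn(C)c(=O)c4ccccc34)n2C)cc1` is not yet measured; against compound 3 the change is (4-isopropoxyphenyl)amino in place of 2,4-dichlorophenoxy on a carbonyl carbon. For the measured compounds named here, the only measured step touching this carbonyl carbon is a 1.9-fold lower number from compound 1 to compound 3 (0.27 log units; within the scatter), where a 2,4-dichlorophenoxy took the place of a (2,4-dibromophenyl)amino and the number stayed within the scatter. Going by the values given here, no measured pair speaks to a 4-isopropoxyphenyl group, so that part of the change is an open question. The carbonyl carbon and the chain to the sulfur are kept, and compound 1 and compound 3 both sit well apart from compound 2. Compound 4 is therefore expected to show a step of a 1.9-fold higher number from compound 3 to compound 4 (0.27 log units; within the scatter), within the scatter. The estimate for compound 4 is 1500 nM, between 500 nM and 5000 nM.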

Compound 4, half-maximal inhibitory concentration: 1100 nM
The estimate for compound 4 lay 1.4-fold (0.13 log units) above the measured number, within the range that was stated.
By their numbers in this assay, from the lowest: compounds 3, 4 and 1 (each within the scatter of the next); then compound 2.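

In this assay, for the compounds shown here, the step of a 1.4-fold lower number from compound 1 to compound 4 (0.13 log units; within the scatter) is the first to change only the aryl group on the amide-type nitrogen, and replacing 2,4-dibromophenyl with 4-isopropoxyphenyl leaves the number within the scatter. The step of a 1.4-fold higher number from compound 3 to compound 4 (0.14 log units; within the scatter) is also within the scatter, so among compounds 1, 3 and 4 neither the halogens on the ring nor the choice of 2,4-dichlorophenoxy or (4-isopropoxyphenyl)amino on the carbonyl carbon separates the values. No supporting data bear on why these changes leave the number within the scatter.

The compounds shown leave open whether an aromatic ring is needed at this position, as a carboxylic acid or a small alkyl amide on the carbonyl carbon would test. Going by these compounds, the effect of a shorter chain to the sulfur also remains open.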